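A few compounds are considered here, and "the series" means these few. Any claim that something is new, unique, unknown or untested is made for them only; others in the source may bear on it.

Among the measured compounds shown here, in a physicochemical assay for lipophilicity (a higher number here means a more lipophilic compound, a lower number a more polar compound), compound 2 `Cc1ccc(-c2cc(C(F)(F)F)ccc2[C@H]2CCOc3cc(S(=O)(=O)Nc4ncc(F)cn4)ccc32)cn1` gives 2.5, the second highest of the three numbers measured so far. Compound 3 `Cc1nc(-c2cc(C(F)(F)F)ccc2[C@H]2CCOc3cc(S(=O)(=O)Nc4ncc(F)cn4)ccc32)co1` stands nearest with 2.8, a gap within the scatter, while compound 1 `Cn1nccc1-c1cc(C(F)(F)F)ccc1[C@H]1CCOc2cc(S(=O)(=O)Nc3ccncn3)ccc21` stands furthest with 1.8, a gap beyond it. For the measured compounds named here, the one measured step that changes a single place, a number 0.30 log units higher from compound 2 to compound 3 (within the scatter), alters a group on an aromatic carbon, not the sulfonamide nitrogen where compound 4 `Cc1ccc(-c2cc(C(F)(F)F)ccc2[C@H]2CCOc3cc(S(=O)(=O)Nc4ccncn4)ccc32)cn1` differs from compound 2: pyrimidin-4-yl in place of 5-fluoropyrimidin-2-yl on a sulfonamide nitrogen. Going by the values given here, no measured step therefore bears directly on this change. Compound 1 carries the same pyrimidin-4-yl group as compound 4 yet differs from compound 2 in a second place too, so its lower number is only a hint. For compound 4 a drop beyond the scatter is expected, a number 0.50 log units lower from compound 2 to compound 4 (beyond the scatter), giving an estimated 2 within a range from 1.6 to 2.4.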

Compound 4, distribution coefficient: 3
The estimate for compound 4 lay 1.00 log units below the measured number; measured number above the stated range.
By their numbers in this assay, from the lowest: compound 1; then compounds 2, 3 and 4 (each within the scatter of the next, the first and the last beyond it).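

In this assay, the sulfonamide nitrogen proves sensitive to its ring: pyrimidin-4-yl in place of 5-fluoropyrimidin-2-yl gives a number 0.50 log units higher from compound 2 to compound 4 (beyond the scatter). With pyrimidin-4-yl held constant, 6-methylpyridin-3-yl in place of 1-methyl-1H-pyrazol-5-yl on an aromatic carbon gives a number 1.20 log units higher from compound 1 to compound 4 (beyond the scatter), so the low number of compound 1 cannot be read as an effect of its sulfonamide ring. Nothing available explains the direction of either step.

Among the compounds shown here, each change appears in only one pair, so whether it would carry over to other partners remains open. Also open, from the compounds shown here alone, is how a plain phenyl group or an amine-bearing ring would read on the sulfonamide nitrogen.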